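A few compounds are considered here, and "the series" means these few. Any claim that something is new, unique, unknown or untested is made for them only; others in the source may bear on it.

Measured so far in an assay for inhibition of 15-hydroxyprostaglandin dehydrogenase [NAD(+)] (Homo sapiens), read by fluorescence, with a stated time of 15 min, in the presence of a further agent that is not named here; on this read-out lower numbers stand for stronger inhibition and higher numbers for weaker inhibition:
- compound 1 `CCCC[S+]([O-])c1sc2nc(-c3nccs3)cc(-c3ccc(C(C)(C)O)cc3)c2c1N`: 3.6 nM
- compound 2 `CCCCS(=O)(=O)c1sc2nc(-c3nccs3)cc(-c3cnc(C)n3C)c2c1N`: 32 nM
- compound 3 `COCCC[S+]([O-])c1sc2nc(-c3nccs3)cc(-c3cnc(C)n3C)c2c1N`: 3.3 nM

Compound 1 stands second highest of the three numbers in this assay. Its nearest neighbour is compound 3, and the two values lie within the scatter of each other, so no order between them can be read. For the measured compounds named here, compound 2 is the furthest; the one step recorded, a 9.7-fold lower number from compound 2 to compound 3 (0.99 log units; beyond the scatter), concerns the substituent on the sulfur, not the aryl group at the other end of the shared core.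

Compound 4 `CCCC[S+]([O-])c1sc2nc(-c3nccs3)cc(-c3ccc(C(=O)OC)cc3)c2c1N` is the next compound, not yet measured in this assay. Against compound 1 the change is methoxycarbonyl in place of 1-hydroxy-1-methylethyl on an aromatic carbon. Going by the values given here, no measured pair alters this part of the molecule, so the single recorded step gives no direct guide; the values of compound 1 and compound 3 show only that the aryl group can be exchanged for a different ring without moving the number beyond the scatter. The step from compound 1 to compound 4 is therefore expected to be small, a 1.9-fold higher number from compound 1 to compound 4 (0.29 log units; within the scatter), with a wide range either way. Compound 4 is estimated at 7 nM, between 2 nM and 40 nM.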

Compound 4, half-maximal inhibitory concentration: 15.1 nM
Estimate against measurement, compound 4: 2.2-fold (0.33 log units) below; the range from low to high includes it.
By their numbers in this assay, from the lowest: compounds 3 and 1 (each within the scatter of the next); then compound 4; then compound 2.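

In this assay, exchanging 4-(1-hydroxy-1-methylethyl)phenyl for 4-(methoxycarbonyl)phenyl gives (a 4.2-fold higher number from compound 1 to compound 4 (0.62 log units; beyond the scatter)), so the group on this six-membered aromatic ring of carbon only, para to a large group, affects the number when the rest of the molecule stays fixed. For the compounds shown here, the earlier compounds held no pair that differed here alone, and their one recorded step concerned the substituent on the sulfur. The two groups have the same heavy-atom count but differ in hydrogen-bond donors and acceptors, and no available evidence explains the step.

The compounds shown do not separate the loss of the donor from the other differences between the two groups, and a carboxylic acid or a primary amide at this position would test this further. As far as these compounds go, whether the step holds with the methoxypropyl chain of compound 3 on the sulfur also remains open.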